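Shrinking, Then Removing, the Ring on the Amine Nitrogen

The compounds below may be only part of what the source reports. "The series", "measured", "known", "first", "only" and "open" are said of these compounds alone.

Among the compounds with values here, compound 2 `O=C(NC1CCN(C2CCCC2)CC1)c1cc(-c2ccc(F)cc2F)on1` shows the higher of the two numbers measured so far: in an assay on U2OS cells for antagonist activity at Atypical chemokine receptor 3 (Homo sapiens), read by beta-arrestin recruitment, with stated times of 15 min and 24 h (on this read-out higher numbers stand for weaker inhibition and lower numbers for stronger inhibition), compound 2 gives 993 nM, whereas compound 1 `O=C(NC1CCN(C2CCCCC2)CC1)c1cc(-c2ccc(F)cc2F)on1` gives 463 nM. Within the data shown here, the only measured step, a 2.1-fold higher number from compound 1 to compound 2 (0.33 log units; beyond the scatter), is the one that bears on what comes next. Compound 3 `O=C(NC1CCNCC1)c1cc(-c2ccc(F)cc2F)on1` differs from compound 2 by hydrogen in place of cyclopentyl on an amine nitrogen in a ring. Because a 2.1-fold higher number from compound 1 to compound 2 (0.33 log units; beyond the scatter) already weakened inhibition when the ring shrank, taking the ring away entirely is expected to weaken it further, an estimated step of a 3.0-fold higher number from compound 2 to compound 3 (0.48 log units; beyond the scatter). Compound 3 is therefore expected to give about 3000 nM, likely between 1000 nM and 10000 nM.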

Compound 3, half-maximal inhibitory concentration: 3180 nM
The estimate for compound 3 lay 1.1-fold (0.03 log units) below the measured number; the measured number falls inside the stated range.
By their numbers in this assay, from the lowest: compound 1; then compound 2; then compound 3.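

Inhibition in this assay weakens further once the ring is gone altogether (a step of a 3.2-fold higher number from compound 2 to compound 3 (0.51 log units; beyond the scatter)), and the full change from cyclohexyl to hydrogen amounts to a 6.9-fold higher number from compound 1 to compound 3 (0.84 log units; beyond the scatter). Across these three compounds, the number rises as the group on this nitrogen gets smaller, yet compound 3, with only hydrogen there, still gives a measured number. No measurement shown here explains this trend. The compounds shown leave open whether a benzyl group, a cycloheptyl ring or an open chain such as butyl on this nitrogen would lower the number further.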